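Aryl sulfonyl piperazine series: swapping the nitro substituent

The source may report more compounds than this note shows. Statements on the series, on what has been measured and on what is new or still open speak of the compounds shown alone.

Measured compounds:
- compound 1, `COc1cc2nc(N3CCN(S(=O)(=O)c4cccc([N+](=O)[O-])c4)CC3)nc(N)c2cc1OC`: 32000 nM
- compound 2, `COc1cc2nc(N3CCN(S(=O)(=O)c4ccc([N+](=O)[O-])cc4)CC3)nc(N)c2cc1OC`: 36000 nM
- compound 3, `COc1cc2nc(N3CCN(S(=O)(=O)c4cc(C(=O)O)c(Cl)cc4Cl)CC3)nc(N)c2cc1OC`: 52000 nM

All three share one core and differ only in the aryl group on the sulfonyl sulfur. In a functional assay on PC-3 cells (Homo sapiens) for inhibition (a lower number here means a stronger inhibitor, a higher number a weaker inhibitor), the three numbers sit close together: a 1.1-fold higher number from compound 1 to compound 2 (0.05 log units; within the scatter), a 1.4-fold higher number from compound 2 to compound 3 (0.16 log units; within the scatter) and a 1.6-fold higher number from compound 1 to compound 3 (0.21 log units; within the scatter) are each within the scatter, so no ordering can be read from them. Compound 2 holds the second highest of the three numbers, nearest to compound 1 and furthest from compound 3, both gaps within the scatter.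

Compound 4, `COc1cc2nc(N3CCN(S(=O)(=O)c4ccc(-c5ccc(S(C)(=O)=O)cc5)cc4)CC3)nc(N)c2cc1OC`, is not yet measured in this assay. It departs from compound 2 by 4-(methylsulfonyl)phenyl in place of nitro on an aromatic carbon. Among the measured compounds shown here, none of the measured steps covers a change of this kind; they only show that the three aryl variants so far give indistinguishable numbers. On that basis no step beyond the scatter is expected, and the estimate for compound 4 is a 1.2-fold lower number from compound 2 to compound 4 (0.08 log units; within the scatter), with the range kept wide. The expected value for compound 4 in this assay is 30000 nM, between 8000 nM and 120000 nM.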

Compound 4, half-maximal inhibitory concentration: 7200 nM
Compound 4: middle estimate off by 4.2-fold (0.62 log units), on the high side; measured number outside the range, below it.
By their numbers in this assay, from the lowest: compound 4; then compounds 1, 2 and 3 (each within the scatter of the next).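

In this assay, among the compounds shown here, 4-(methylsulfonyl)phenyl in place of nitro on this aromatic carbon, para to a large group, gives the first step beyond the scatter (a 5.0-fold lower number from compound 2 to compound 4 (0.70 log units; beyond the scatter)). The earlier aryl variations, compound 1, compound 2 and compound 3, gave numbers that could not be told apart, whereas this position does respond to a change that adds a six-membered aromatic ring of carbon only. No measurement available here accounts for the step.

Going by these compounds, it remains open whether the step depends on the added aromatic ring or on the methylsulfonyl group it carries. An unsubstituted phenyl at the same place would separate these two, and an amine on the outer ring would show whether the methylsulfonyl group can be exchanged.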